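A Carboxy Extension on a Bridged Bicyclic Amide Acid

A few compounds are considered here, and "the series" means these few. Any claim that something is new, unique, unknown or untested is made for them only; others in the source may bear on it.

Compound 1 `CCCNC(=O)C1C(C(=O)O)[C@@H]2CC[C@H]1O2`: 10000 nM
Compound 2 `Cc1cc(C)c(NC(=O)C2C(C(=O)O)[C@@H]3CC[C@H]2O3)c(C)c1`: 10000 nM
Compound 3 `C/C(=N/Nc1ccccc1)c1ccccc1NC(=O)C1C(C(=O)O)[C@@H]2CC[C@H]1O2`: 10000 nM

Of the compounds shown here, three sharing the same core have been tested in an ADME assay on SJ-G2 cells (Homo sapiens) for cytotoxicity, read by MTT assay, with a stated time of 72 h; on this read-out lower numbers stand for stronger inhibition of growth and higher numbers for weaker inhibition of growth. Compound 1 gives 10000 nM in this assay. Compound 2 gives 10000 nM, and compound 3 gives 10000 nM. At the digits reported, compound 1 stands level with compound 2 and with compound 3; the gaps between all three lie within the scatter, so no order among them can be read, and none of them can be called the stronger or the weaker.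

Compound 4 `O=C(O)CCCNC(=O)C1C(C(=O)O)[C@@H]2CC[C@H]1O2` has not yet been measured in this assay. Set against compound 1, the change is carboxy in place of hydrogen on a saturated chain carbon, three bonds along the chain from an amide-type nitrogen. For the measured compounds named here, no step between two measured compounds is available to guide what such a change might do, and the three measured compounds differ widely at the amide nitrogen yet return the same figure. On that ground the step is expected to be none beyond the scatter, and the estimated step of no change at the digits printed from compound 1 to compound 4 (within the scatter) reflects this. Compound 4 is therefore estimated to give 10000 nM in this assay, with an expected range from 5000 nM to 20000 nM.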

Compound 4, concentration for 50% growth inhibition: 10000 nM
For compound 4 middle estimate and measured number coincide at the digits printed; measured number inside the range.
By their numbers in this assay, from the lowest: compounds 1, 2, 3 and 4 (each within the scatter of the next).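

For the compounds shown here, measured in this assay the change of propyl to 3-carboxypropyl gives no change at the digits printed from compound 1 to compound 4 (within the scatter) and this is the first step between two measured compounds that differ in one place. Compound 1, compound 2 and compound 3 shared one figure despite differing widely at the amide nitrogen, but none of them isolated a single change; this pair shows that carboxy in place of hydrogen on a saturated chain carbon, three bonds along the chain from an amide-type nitrogen, does not move the number beyond the scatter. No measurement available here accounts for this result.

Going by these compounds, it remains open whether an amine, a hydroxy group or a longer chain ending in a carboxylic acid at this same place would leave the figure as it stands. All four compounds return one figure, so the compounds shown include no change at the amide nitrogen that moves the number, and they leave open what such a change would be.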